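A Furanyl Addition on the Five-Membered Ketone Heterocycle

This account rests on a few compounds, and the source may have more. Where it says the series, first, only, none or still open, it means among the compounds named here.

Of the compounds shown here, three have been tested in an assay on HEK-293T cells for inhibition of diacylglycerol lipase-alpha (Homo sapiens), read by colorimetric assay; on this read-out higher numbers stand for weaker inhibition and lower numbers for stronger inhibition. Compound 1 `O=C(CCCCCc1ccccc1)c1nc2ncccc2[nH]1` gives 1230 nM. Compound 2 `O=C(CCCCCc1ccccc1)c1nc2ccc(Br)cc2o1` gives 5890 nM. Compound 3 `O=C(CCCCCCc1ccccc1)c1nncs1` reaches only a limit, > 10000 nM. Compound 3 thus stands at the bottom of the numbers shown, (the limit of > 10000 nM in this assay, at which 1 of the 3 values shown sits). Compound 4 `O=C(CCCCCCc1ccccc1)c1nnc(-c2ccco2)s1` differs from compound 3 in one place: furan-2-yl in place of hydrogen on an aromatic carbon. Within the data shown here, no measured step between two compounds resembles this change, and the expectation rests on the limit alone. With compound 3 at the limit, the step to compound 4 can only show as a gain or as nothing. A modest gain beyond the scatter is expected for compound 4, an at least 3.3-fold lower number from compound 3 to compound 4 (0.52 log units; beyond the scatter). Compound 4 is estimated at 3000 nM, with a range from 800 nM to 10000 nM.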

Compound 4, half-maximal inhibitory concentration: > 10000 nM
Compound 4: a limit, no number (the forecaster's own chance of this, stated with the estimate: 30%); middle value at least 3.3-fold (0.52 log units) from the limit.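

Compound 3 and compound 4 both end at a limit rather than a number, so no step between them can be read: the limit of > 10000 nM in this assay, at which 2 of the 4 values shown sit.

On these data alone, whether furan-2-yl in place of hydrogen changes the inhibition at all remains open.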